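The compounds below may be only part of what the source reports. "The series", "measured", "known", "first", "only" and "open" are said of these compounds alone.

Measured so far in a functional assay on A2780 cells (Homo sapiens) for antiproliferative activity, read by fluorescence, with a stated time of 72 h; a lower number here means a stronger inhibitor, a higher number a weaker inhibitor:
Compound 1 `CN1CCC(C(=O)N2Cc3c(NC(=O)c4ccco4)n[nH]c3C2(C)C)CC1` gives > 5000 nM, a limit of this assay and not a number.
Compound 2 `CC(C)CC(=O)Nc1n[nH]c2c1CN(C(=O)C1CCN(C3CC3)CC1)C2(C)C` gives 320 nM.
Compound 3 `CN1CCN(C(=O)N2Cc3c(NC(=O)c4ccc(F)cc4)n[nH]c3C2(C)C)CC1` gives 180 nM.

For the measured compounds named here, compound 1 stands at the limit of > 5000 nM in this assay, at which 1 of the 3 values shown sits, so only an upper bound on its potency is known, and no step to another compound can be sized from it. Compound 4 `CN1CCC(C(=O)N2Cc3c(NC(=O)NCc4ccccc4)n[nH]c3C2(C)C)CC1` differs from compound 1 in one place: benzylamino in place of furan-2-yl on a carbonyl carbon. Going by the values given here, with no measured pair sharing this change, the size of the step is open; the benzylamino group is expected to move the value into the measured range of the series, an improvement rather than none. The expected step of an at least 2.5-fold lower number from compound 1 to compound 4 (0.39 log units; beyond the scatter) is a guess with wide uncertainty. Compound 4 is estimated at 2000 nM, between 300 nM and 10000 nM.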

Compound 4, half-maximal inhibitory concentration: 2680 nM
The estimate for compound 4 lay 1.3-fold (0.13 log units) below the measured number; the measured number falls inside the stated range.
By their numbers in this assay, from the lowest: compounds 3 and 2 (each within the scatter of the next); then compound 4. At a limit, above all of these: compound 1.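

In this assay compound 1 gives > 5000 nM as a limit and not a number. On this carbonyl carbon, benzylamino in place of furan-2-yl gives an at least 1.8-fold lower number from compound 1 to compound 4 (0.27 log units; that floor lies within the scatter) as a floor only, so the true size of the change stays unread. For the compounds shown here, compound 4 at 2680 nM is the first real number for this place with the rest of compound 1 held fixed.

Open, as far as these compounds go, is how anilino or phenethylamino would read on the same carbonyl carbon. Also open, from the compounds shown here alone, is whether plain phenyl in place of benzylamino would give a number at all.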